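The source may report more compounds than this note shows. Statements on the series, on what has been measured and on what is new or still open speak of the compounds shown alone.

Measured so far:
compound 1 `O=C(Nc1ccc(Br)cc1F)c1cc(I)ccc1O` gives 8400 nM in an ADME assay on RAW264.7 cells (Mus musculus) for cytotoxicity, read by MTT assay, with a stated time of 24 h; on this read-out higher numbers stand for lower toxicity in this test and lower numbers for higher toxicity in this test.
compound 2 `O=C(Nc1ccc(Br)cc1F)c1cc(Cl)ccc1O` gives 7800 nM in this assay.
compound 3 `O=C(Nc1ccc(I)cc1F)c1cc(I)ccc1O` gives 6000 nM in this assay.

Compound 4 `O=C(Nc1ccc(I)cc1F)c1cc(Cl)ccc1O` has not yet been run in this assay. It differs from compound 3 by chloro in place of iodo on an aromatic carbon. The same change has been made once before, between compound 1 and compound 2: chloro in place of iodo on an aromatic carbon. The place is described in the same words in both cases, so this is the same change, not merely the same kind. Its measured step was a 1.1-fold lower number from compound 1 to compound 2 (0.03 log units; within the scatter). The two cores differ by iodo in place of bromo on an aromatic carbon, a step that gave a 1.4-fold lower number from compound 1 to compound 3 (0.15 log units; within the scatter). Going by the values given here, for compound 2 and compound 3 no step is worked out; their two values sit close to one another.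

With only one earlier occurrence, the step from compound 3 to compound 4 in this assay is expected at a 1.1-fold lower number from compound 3 to compound 4 (0.03 log units; within the scatter), beside the earlier 1.1-fold lower number from compound 1 to compound 2 (0.03 log units; within the scatter), and this rests on that one measured occurrence alone. Compound 4 is therefore estimated at 5600 nM in this assay, expected to fall between 3000 nM and 10500 nM.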

Compound 4, half-maximal cytotoxic concentration: 7600 nM
The estimate for compound 4 lay 1.4-fold (0.13 log units) below the measured number; low and high end bracket the measured number.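

In this assay, chloro in place of iodo on an aromatic carbon gives a 1.3-fold higher number from compound 3 to compound 4 (0.10 log units; within the scatter), and this step does not differ from its earlier occurrence on the other core: the same change on two cores in this assay, a 1.1-fold lower number (0.03 log units; within the scatter) from compound 1 to compound 2 and a 1.3-fold higher number (0.10 log units; within the scatter) from compound 3 to compound 4, 1.4-fold (0.13 log units) apart, within the scatter of two such steps. Iodo in place of bromo gives a 1.0-fold lower number from compound 2 to compound 4 (0.01 log units; within the scatter), and it reads the same way across the two cores: the same change on two cores in this assay, a 1.4-fold lower number (0.15 log units; within the scatter) from compound 1 to compound 3 and a 1.0-fold lower number (0.01 log units; within the scatter) from compound 2 to compound 4, 1.4-fold (0.13 log units) apart, within the scatter of two such steps. Both changes therefore carry from one core to the other only in the limited sense that every step stays within the scatter; this does not fix a direction for either change, and it does not show how a step beyond the scatter would carry over.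

The four compounds vary only among chloro, bromo and iodo, so they give no view of how far the read-out can move in this series. As far as these compounds go, whether an amine or a carboxylic acid on the aromatic carbon para to a hydroxy group would give a step beyond the scatter, and whether that step would carry between these cores, remains open.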